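The compounds below may be only part of what the source reports. "The series", "measured", "known", "first", "only" and "open" are said of these compounds alone.

Measured compounds:
compound 1, `Cc1ccc(-c2ccc3c(c2)C(=O)C(=O)N3)cc1`; in a functional assay on K562 cells (Homo sapiens) for antiproliferative activity, read by MTT assay, with a stated time of 48 h (on this read-out lower numbers stand for stronger inhibition and higher numbers for weaker inhibition), compound 1 gives > 10000 nM, which is a limit of the assay and not a number.
compound 2, `CCN1C(=O)C(=O)c2cc(-c3ccc(OC)cc3)ccc21`; in this assay compound 2 gives 2200 nM.
compound 3, `C=CCN1C(=O)C(=O)c2cc(-c3ccc(OC)cc3)ccc21`; in this assay compound 3 gives 390 nM.

Compound 2 stands at the highest of the two numbers in this assay; compound 1 sits only at the limit of > 10000 nM in this assay, at which 1 of the 3 values shown sits. Its nearest neighbour is compound 3, reached by a 5.6-fold lower number from compound 2 to compound 3 (0.75 log units; beyond the scatter), a modest step beyond the scatter.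

Compound 4, `COc1ccc(-c2ccc3c(c2)C(=O)C(=O)N3Cc2ccc(Cl)cc2)cc1`, differs from compound 2 by 4-chlorophenyl in place of methyl on a saturated chain carbon bound to an amide-type nitrogen in a ring. Read one bond further out, the change is ethyl to 4-chlorobenzyl. Among the measured compounds shown here, the only measured step at this place is the one from compound 2 to compound 3, which lowered the number beyond the scatter when the saturated chain carbon carried a larger group. On that single precedent a step of similar size and direction, a lower number, is expected in this assay, namely a 4.4-fold lower number from compound 2 to compound 4 (0.64 log units; beyond the scatter). Compound 4 is therefore estimated at 500 nM, with a range from 100 nM to 3000 nM.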

Compound 4, half-maximal inhibitory concentration: 350 nM
For compound 4 the middle estimate is 1.4-fold (0.15 log units) above the measured one, within the range that was stated.
By their numbers in this assay, from the lowest: compounds 4 and 3 (each within the scatter of the next); then compound 2. At a limit, above all of these: compound 1.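

At this position in this assay, a second replacement of methyl, this time by 4-chlorophenyl, also lowers the number, giving a 6.3-fold lower number from compound 2 to compound 4 (0.80 log units; beyond the scatter), so the lowering seen earlier with vinyl is not tied to vinyl alone. Exchanging vinyl for 4-chlorophenyl gives a 1.1-fold lower number from compound 3 to compound 4 (0.05 log units; within the scatter), so the two groups cannot be told apart in this read-out, even though 4-chlorophenyl brings a six-membered aromatic ring of carbon only. The saturated chain carbon bound to the amide-type nitrogen in a ring thus carries this ring with no loss against vinyl.

On these data alone, whether the chlorine contributes remains open, as does what an unsubstituted benzyl, a longer chain or an amine would give at this place. Nothing measured among these compounds bears on what lies behind these steps.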